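A few compounds are considered here, and "the series" means these few. Any claim that something is new, unique, unknown or untested is made for them only; others in the source may bear on it.

Compound 1 `CC(Oc1c(N)ncc2c(-c3cnn(C4CCNCC4)c3)coc12)c1cc(F)ccc1Cl`: 6400 nM
Compound 2 `CC(Oc1c(N)ncc2c(-c3cnn(C4CCNCC4)c3)coc12)c1c(Cl)ccc(Cl)c1Cl`: 1300 nM

Both values come from a functional assay on MKN-45 cells (Homo sapiens) for antiproliferative activity, read by CellTiter-Glo, with a stated time of 3 days; on this read-out lower numbers stand for stronger inhibition and higher numbers for weaker inhibition. Of the two, compound 2 has the lower number. For the measured compounds named here, the only measured step is a 4.9-fold lower number from compound 1 to compound 2 (0.69 log units; beyond the scatter), and it is modest.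

The next compound is compound 3 `CC(Oc1c(N)ncc2c(-c3cnn(C4CCNCC4)c3)coc12)c1c(Br)ccc(F)c1Cl`, which differs from compound 2 as follows: a group of 9 heavy atoms (6 carbon, 1 fluorine, 1 chlorine, 1 bromine; one six-membered aromatic ring of carbon only) in place of a group of 9 heavy atoms (6 carbon, 3 chlorine; one six-membered aromatic ring of carbon only), on a saturated chain carbon bound to an oxygen on an aromatic ring and a saturated chain carbon. The change lies on a saturated chain carbon bound to an oxygen on an aromatic ring and a saturated chain carbon, the same place as in the measured step. Both groups hold 9 heavy atoms and one six-membered aromatic ring of carbon only. That single step shows that this place can move the number modestly, but it gives no direction for the present exchange. No step beyond the scatter is therefore expected in this assay. The expected change is a 1.1-fold lower number from compound 2 to compound 3 (0.03 log units; within the scatter). The estimate for compound 3 is 1200 nM, with an expected range of 450 nM to 3200 nM.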

Compound 3, half-maximal inhibitory concentration: 510 nM
The estimate for compound 3 lay 2.4-fold (0.37 log units) above the measured number, and the stated range covers the measured number.
By their numbers in this assay, from the lowest: compound 3; then compound 2; then compound 1.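

In this assay the exchange of a ring with three chlorines for one with fluorine, chlorine and bromine, at an unchanged count of 9 heavy atoms, still gives a 2.5-fold lower number from compound 2 to compound 3 (0.41 log units; beyond the scatter) and so shows that this place responds to which halogens the ring holds, not only to the size of the group. For the compounds shown here, the span at this place now reaches a 13-fold lower number from compound 1 to compound 3 (1.10 log units; beyond the scatter) and is large, where the earlier compounds showed only a modest step.

The compounds shown do not separate the part played by the bromine from that of the fluorine, as both differ at once between the two rings. They also leave open how a ring carrying an amine or a methoxy group would read at this place. Nothing at hand gives a reason for either step.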